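The source may hold more compounds than are shown below. What is called first, only, known or untested is meant among the compounds shown, and "the series" means these compounds.

Compound 2 `Cc1cccc(-c2cn3ccnc3c(-c3ccc4ncn(Cc5ccccc5)c4c3)n2)c1` was examined in a functional assay on NCI-H460 cells (Homo sapiens) for inhibition, read by sulforhodamine B assay, with a stated time of 48 h, tested at 10 uM (on this read-out higher numbers stand for more inhibition at the one concentration tested (going by the name of the read-out) and lower numbers for less inhibition), where compound 2 gives 10.1%. Among the measured compounds shown here, compound 1 `CC(=O)c1ccc(-c2cn3ccnc3c(-c3ccc4ncn(C5CCCCC5)c4c3)n2)cc1` differs from it at more than one place, so no single step connects the two; in this assay compound 1 gives 7.12%, and the two values lie within the usual scatter of each other, so the numbers do not separate them. Both readings stand low at the one concentration tested.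

Compound 3 `c1ccc(Cn2cnc3ccc(-c4nc(-c5cccc6ccccc56)cn5ccnc45)cc32)cc1` has not yet been measured in this assay. It differs from compound 2 at a single place: naphthalen-1-yl in place of 3-methylphenyl on an aromatic carbon. For the measured compounds named here, no measured pair in the set isolates this change, so there is no recorded step to lean on. Because compound 2 gives only 10.1% and compound 1 sits close by, the step of a number 2.9 percentage points higher from compound 2 to compound 3 (within the scatter) is expected to be small, within the scatter, with at most a modest movement in either direction. Compound 3 is accordingly expected to give 13% in this assay, with a range from 0% to 32%.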

Compound 3, a percentage reported as inhibition, at one concentration (the size of the read-out at that concentration, not a potency): 3.8%
For compound 3 the middle estimate is 9.2 percentage points above the measured one; the measured number falls inside the stated range.
By their numbers in this assay, from the lowest: compounds 3, 1 and 2 (each within the scatter of the next).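

In this assay, among the compounds shown here, naphthalen-1-yl in place of 3-methylphenyl on the aromatic carbon next to the ring nitrogen gives a number 6.3 percentage points lower from compound 2 to compound 3 (within the scatter), and this is the first single-place step available for this position. Going from one six-membered aromatic ring of carbon only to two at this position therefore does not separate the two compounds, and both readings stay low at the one concentration tested. Nothing measured here accounts for these readings or says what this position contributes to them.

The compounds shown leave open whether a group of another kind on this carbon, such as an amine or a carboxylic acid, would give a reading that stands clear of the scatter, as every group here is aromatic and carbon-based at its point of attachment. For the compounds shown here, they also leave open what the benzyl and cyclohexyl groups on the far side of the core contribute on their own, as compound 1 differs from the other compounds at more than one place and no single step isolates that change.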